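From Phenyl to Trimethoxyphenyl: an Expected Small Step

This account rests on a few compounds, and the source may have more. Where it says the series, first, only, none or still open, it means among the compounds named here.

Compound 1, `CC(C)=CCC/C(C)=C/CC/C(C)=C/CC[C@@H]1[C@@]2(C)CC/C(=N\OCc3cn(-c4ccccc4C#N)nn3)C(C)(C)[C@@H]2CC[C@@]1(C)O`, gives 21200 nM in a functional assay on HeLa cells (Homo sapiens) for cytotoxicity, read by MTT assay, with a stated time of 48 h; a lower number here means a stronger inhibitor, a higher number a weaker inhibitor.
Compound 2, `CC(C)=CCC/C(C)=C/CC/C(C)=C/CC[C@@H]1[C@@]2(C)C/C(=C\c3ccc(OCc4cn(-c5ccccc5)nn4)cc3)C(=O)C(C)(C)[C@@H]2CC[C@@]1(C)O`, gives 36300 nM in this assay.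

Of these two numbers, compound 2 holds the highest, yet its gap to compound 1 lies within the usual scatter of repeated measurements, so the two cannot be told apart. Compound 3, `COc1cc(OC)c(-n2cc(COc3ccc(/C=C4\C[C@]5(C)[C@@H](CC/C=C(\C)CC/C=C(\C)CCC=C(C)C)[C@](C)(O)CC[C@H]5C(C)(C)C4=O)cc3)nn2)c(OC)c1`, has not yet been measured. It differs from compound 2 in one place: 2,4,6-trimethoxyphenyl in place of phenyl on an aromatic nitrogen. Within the data shown here, no step between measured compounds is known that would show how such a change moves the number, so no shift beyond the scatter is expected in this assay. Compound 3 is estimated to give 30000 nM, with a range from 10000 nM to 90000 nM. The expected step is a 1.2-fold lower number from compound 2 to compound 3 (0.08 log units; within the scatter), within the scatter.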

Compound 3, half-maximal inhibitory concentration: 17500 nM
Estimate against measurement, compound 3: 1.7-fold (0.23 log units) above; the measured number falls inside the stated range.
By their numbers in this assay, from the lowest: compounds 3, 1 and 2 (each within the scatter of the next, the first and the last beyond it).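

On an aromatic nitrogen of the five-membered ring, the group carried there can move the number: 2,4,6-trimethoxyphenyl in place of phenyl brings a 2.1-fold lower number from compound 2 to compound 3 (0.32 log units; beyond the scatter) in this assay, a modest step, yet beyond the scatter. This position therefore accepts the larger group with no loss of activity in these cells. Nothing measured here explains this step. Still open, going by these compounds, is whether an amine or a carboxylic acid on the phenyl ring would move the number as far, or in the opposite direction.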